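This account rests on a few compounds, and the source may have more. Where it says the series, first, only, none or still open, it means among the compounds named here.

Compound 1 `O=C(O)c1ccc(CCCN2C(=O)CC[C@@H]2CCC(O)Cc2ccc3ccccc3c2)s1`: 500 nM in a functional assay on HEK293 cells with prostaglandin E2 receptor EP4 subtype (Rattus norvegicus) as the target, read by cAMP accumulation; on this read-out lower numbers stand for an effect already at smaller amounts and higher numbers for an effect only at larger amounts of compound
Compound 2 `O=C(O)CCCCCCN1C(=O)CC[C@@H]1CC[C@@H](O)Cc1cccc(-c2ccccc2)c1`: 195 nM

Of these two numbers, compound 2 has the lower one, and compound 1 sits a step above it that lies beyond the usual scatter. Compound 3 `O=C(O)CCCCCCN1C(=O)CC[C@@H]1CC[C@@H](O)Cc1cccc(OC(F)(F)F)c1` is not yet measured; it differs from compound 2 by trifluoromethoxy in place of phenyl on an aromatic carbon. For the measured compounds named here, no pair of measured compounds that differ in only one place is available, so the effect of this change cannot be read from the data. The step of a 1.3-fold higher number from compound 2 to compound 3 (0.12 log units; within the scatter) is expected to be small and toward a somewhat higher number. The estimate for compound 3 is 260 nM, with a range from 60 nM to 1100 nM.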

Compound 3, half-maximal effective concentration: 50 nM
Beside the measured number, compound 3's estimate is 5.2-fold (0.72 log units) above it, outside the stated range (below it).
By their numbers in this assay, from the lowest: compound 3; then compound 2; then compound 1.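

Putting trifluoromethoxy in place of phenyl on this aromatic carbon gives a 3.9-fold lower number from compound 2 to compound 3 (0.59 log units; beyond the scatter) in this assay. So a second aromatic ring is not needed at this place for an effect at smaller amounts, and a group with no ring serves better here. Nothing shown gives a reason for this step.

As far as these compounds go, it stays open whether the oxygen, the fluorines or the loss of the ring matters most. A methoxy group, a trifluoromethyl group or a chlorine atom at the same place would help separate these.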